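A few compounds are considered here, and "the series" means these few. Any claim that something is new, unique, unknown or untested is made for them only; others in the source may bear on it.

Measured so far:
- compound 1, `CSc1ccc(C)cc1NCC1=NCCN1`, gives 8.91 nM
- compound 2, `CS(=O)(=O)c1ccc(C(F)(F)F)cc1NCC1=NCCN1`, gives < 10000 nM
- compound 3, `CSc1ccc(Cl)cc1NCC1=NCCN1`, gives 2.82 nM

In a functional assay on CHO cells for agonist activity at Alpha-2C adrenergic receptor (Homo sapiens) (a higher number here means that more compound is needed for the effect, a lower number that less compound is needed), compound 3 gives 2.82 nM, the lowest of the two numbers shown. Its nearest neighbour is compound 1, and the step of a 3.2-fold lower number from compound 1 to compound 3 (0.50 log units; beyond the scatter) comes from chloro in place of methyl on an aromatic carbon. Within the data shown here, the value of compound 2 in this assay is a limit of the assay and not a number, so it offers no step to compare.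

Compound 4, `CSc1ccc(C(F)(F)F)cc1NCC1=NCCN1`, has not yet been measured in this assay. It differs from compound 3 as follows: trifluoromethyl in place of chloro on an aromatic carbon

Among the measured compounds shown here, the only measured step that bears on this change is the one from compound 1 to compound 3, where exchanging the group on that aromatic carbon shifted the number by a modest amount. Compound 4 carries a trifluoromethyl where compound 3 carries chloro, so a step of similar size, or smaller, is expected, with the direction uncertain; a modest upward movement is taken as the central case.

The expected step from compound 3 to compound 4 in this assay is therefore a 2.1-fold higher number from compound 3 to compound 4 (0.33 log units; beyond the scatter). Compound 4 is estimated to give 6 nM in this assay, with a range from 1.5 nM to 25 nM.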

Compound 4, half-maximal effective concentration: 7.94 nM
For compound 4 the middle estimate is 1.3-fold (0.12 log units) below the measured one; the measured number falls inside the stated range.
By their numbers in this assay, from the lowest: compound 3; then compounds 4 and 1 (each within the scatter of the next).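

In this assay, the aromatic carbon para to the methylsulfanyl group now carries three different groups, and trifluoromethyl does not match chloro there, with a 2.8-fold higher number from compound 3 to compound 4 (0.45 log units; beyond the scatter). Set against methyl, trifluoromethyl brings no difference that can be told from the scatter, with a 1.1-fold lower number from compound 1 to compound 4 (0.05 log units; within the scatter), so among these three groups only chloro stands apart, its steps to both of the others lying beyond the scatter. Compound 2 holds a limit of the assay and not a number, so the step from it to compound 4, methylsulfanyl in place of methylsulfonyl, cannot be read, and the size of that exchange stays unknown: the limit of < 10000 nM in this assay, at which 1 of the 4 values shown sits.

The three groups compared at this position say nothing about how an amine, a methoxy group or a nitrile would behave on the same carbon. On these data alone, it also remains open how the group on sulfur can vary, for instance whether an ethylsulfanyl or a methylsulfinyl group in place of methylsulfanyl would keep a number close to those of compound 3 and compound 4.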